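The source may hold more compounds than are shown below. What is called first, only, known or untested is meant among the compounds shown, and "the series" means these compounds.

Of the compounds shown here, two built on a shared core have been tested in a functional assay on HeLa cells (Homo sapiens) for inhibition, read by MTT assay, with a stated time of 48 h; on this read-out higher numbers stand for weaker inhibition and lower numbers for stronger inhibition. Compound 1, `COc1ccc(CNC(=O)/C=C/c2coc3cc(O)ccc3c2=O)cc1`, gave only a limit of the assay, > 100000 nM. Among the compounds with values here, compound 2, `COc1cccc(NC(=O)/C=C/c2coc3cc(OC)ccc3c2=O)c1`, gave 19200 nM, which makes it the only compound here with an actual number. Compound 3, `COc1ccc2c(=O)c(/C=C/C(=O)NCc3ccc(C)cc3)coc2c1`, keeps the core of compound 2 and changes one group: 4-methylbenzyl in place of 3-methoxyphenyl on an amide-type nitrogen. Within the data shown here, no measured pair shows a single change of this kind, so any forecast must stay loose. With compound 2 at 19200 nM as the only anchor, a slight loss of inhibition seems more likely than a gain. The expected change is a 2.1-fold higher number from compound 2 to compound 3 (0.32 log units; beyond the scatter), a small step toward weaker inhibition, close to the usual scatter. For compound 3 the estimated value is 40000 nM, with an expected range from 12000 nM to 100000 nM.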

Compound 3, half-maximal inhibitory concentration: > 100000 nM
Compound 3 gave a limit, no number (the forecaster's own chance of this, stated with the estimate: 30%); middle value at least 2.5-fold (0.39 log units) away from the limit.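

Within the data shown here, replacing 3-methoxyphenyl with 4-methylbenzyl on the amide-type nitrogen gives an at least 5.2-fold higher number from compound 2 to compound 3 (0.71 log units; beyond the scatter) in this assay, the first single change that can be read. It shows that this position does not tolerate every aromatic group of the same heavy-atom count, since the change weakens inhibition beyond the usual scatter. Compound 3 gives only a limit of the assay, so the step marks a minimum and its full size stays unknown: the limit of > 100000 nM in this assay, at which 2 of the 3 values shown sit.

The swap alters several features at once, so the compounds shown leave open whether the loss follows from the benzyl form, from the methyl group or from the missing methoxy oxygen. A 3-methoxybenzyl or a 4-methylphenyl group on the same nitrogen would help to separate these possibilities.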